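Bromo for Cyclopropylmethoxy on a Stilbene-Type Chromone

The compounds below may be only part of what the source reports. "The series", "measured", "known", "first", "only" and "open" are said of these compounds alone.

Going by the values given here, in a functional assay on A549 cells (Homo sapiens) for antiproliferative activity, read by MTT assay, with a stated time of 12 h (on this read-out higher numbers stand for weaker inhibition and lower numbers for stronger inhibition), compound 1 `COc1cc(OC)c2c(=O)cc(/C=C/c3ccc(OCC4CC4)cc3)oc2c1` gives 20900 nM, the only numerical value in this set. Compound 2 `COc1ccc2c(=O)cc(/C=C/c3ccc(OC(F)(F)F)cc3)oc2c1` reaches only the limit > 40000 nM in this assay. Compound 3 `COc1cccc2oc(/C=C/c3ccc(OC(F)(F)F)cc3)cc(=O)c12` likewise reaches only the limit > 40000 nM. Two of three results therefore sit at the limit of > 40000 nM in this assay, at which 2 of the 3 values shown sit, which leaves compound 1 as the sole fixed point. Compound 4 `COc1cc(OC)c2c(=O)cc(/C=C/c3ccc(Br)cc3)oc2c1` differs from compound 1 by bromo in place of cyclopropylmethoxy on an aromatic carbon. Among the compounds with values here, no measured pair isolates this change, so a step of a 1.2-fold higher number from compound 1 to compound 4 (0.08 log units; within the scatter) is expected, within the usual scatter or slightly toward weaker inhibition. Compound 4 is thus estimated at 25000 nM, with a range from 8000 nM to 80000 nM.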

Compound 4, half-maximal inhibitory concentration: > 40000 nM
Compound 4: a limit, no number; the forecaster's own chance of this, stated with the estimate: 30%; middle value at least 1.6-fold (0.20 log units) away from the limit.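

Going by these compounds alone, this is the first comparison at this position, on an aromatic carbon para to a large group, and bromo in place of cyclopropylmethoxy gives an at least 1.9-fold higher number from compound 1 to compound 4 (0.28 log units; that floor lies within the scatter). Compound 4 has only a limit and no number, so the step is a floor, and the true size of the change cannot be read. The set now gathers at one limit, with compound 1 still the sole fixed point: the limit of > 40000 nM in this assay, at which 3 of the 4 values shown sit.

The compounds shown leave open whether an amine or a longer ether chain at this position would give a measurable value on the shared core.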